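Chlorophenyl position and cytotoxicity on two cores

This account rests on a few compounds, and the source may have more. Where it says the series, first, only, none or still open, it means among the compounds named here.

Compound 1, `Cc1cc(OCC(=O)Nc2ccc(Cl)cc2)nc(Nc2ccc(C#N)cc2)n1`: 2630 nM
Compound 2, `Cc1cc(OCC(=O)Nc2cccc(Cl)c2)nc(Nc2ccc(C#N)cc2)n1`: 32200 nM
Compound 3, `Cc1cnc(Nc2ccc(C#N)cc2)nc1OCC(=O)Nc1ccc(Cl)cc1`: > 317000 nM

In an ADME assay on MT4 cells (Homo sapiens) for cytotoxicity, read by MTT assay, with a stated time of 5 days (on this read-out lower numbers stand for higher toxicity in this test and higher numbers for lower toxicity in this test), compound 1 gives 2630 nM and compound 2 gives 32200 nM. The change 3-chlorophenyl in place of 4-chlorophenyl on an amide-type nitrogen gave a 12-fold higher number from compound 1 to compound 2 (1.09 log units; beyond the scatter). Compound 3 reaches only a limit of this assay, (the limit of > 317000 nM in this assay, at which 1 of the 3 values shown sits). The difference between the core of compound 1 and the core of compound 3 is not broken down here. Compound 4, `Cc1cnc(Nc2ccc(C#N)cc2)nc1OCC(=O)Nc1cccc(Cl)c1`, carries the same change on the core of compound 3: 3-chlorophenyl in place of 4-chlorophenyl on an amide-type nitrogen. Since compound 3 already sits at a limit, compound 4 is expected to give 450000 nM. A step that the limit leaves unreadable from compound 3 to compound 4 is expected, resting on a 12-fold higher number from compound 1 to compound 2 (1.09 log units; beyond the scatter) and on the limit (the limit of > 317000 nM in this assay, at which 1 of the 3 values shown sits).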

Compound 4, half-maximal cytotoxic concentration: 144000 nM
Compound 4: the middle estimate sits 3.1-fold (0.49 log units) above what was measured, and the stated range ends above it.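

In this assay, the change to 3-chlorophenyl from 4-chlorophenyl on an amide-type nitrogen gave an at least 2.2-fold lower number from compound 3 to compound 4 (0.34 log units; beyond the scatter), so the change did not carry over from the core of compound 1 to the core of compound 3 in direction or size: the same change on two cores in this assay, a 12-fold higher number (1.09 log units; beyond the scatter) from compound 1 to compound 2 and an at least 2.2-fold lower number (0.34 log units; beyond the scatter) from compound 3 to compound 4, at least 26-fold (1.43 log units) apart, beyond the scatter of two such steps

The value of compound 3 is a limit, not a number: the limit of > 317000 nM in this assay, at which 1 of the 4 values shown sits.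

The step on this core is therefore only a bound, and with one pair on each core the result does not show why the two cores differ or how the change would behave on any other core.

The compounds shown leave open whether a fluorophenyl or a methoxyphenyl on the amide-type nitrogen would also give opposite steps on the two cores.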